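The source may hold more compounds than are shown below. What is called first, only, known or untested is meant among the compounds shown, and "the series" means these compounds.

Of the compounds shown here, three of the shared core have been measured in a functional assay on MCF7 cells (Homo sapiens) for inhibition, read by MTT assay, with a stated time of 72 h; a higher number here means a weaker inhibitor, a lower number a stronger inhibitor. Compound 1 `CN(C(=O)NC(=O)c1ccc(Cl)cc1Cl)c1nc(C(F)(F)F)c(C(=O)N/N=C/c2cccc(C(F)(F)F)c2)s1` gives 10.7 ug/mL, compound 2 `CN(C(=O)NC(=O)c1ccccc1F)c1nc(C(F)(F)F)c(C(=O)N/N=C/c2cc(C(F)(F)F)cc(C(F)(F)F)c2)s1` gives 6.16 ug/mL, and compound 3 `Cc1nc(N(C)C(=O)NC(=O)c2c(F)cccc2F)sc1C(=O)N/N=C/c1cccc(C(F)(F)F)c1` gives 28.2 ug/mL. Compound 2 holds the lowest of the three numbers; its gap to compound 1 lies within the scatter, while its gap to compound 3 lies beyond it, so only compound 3 can be set apart as the weaker inhibitor of the three.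

Compound 4 `CN(C(=O)NC(=O)c1ccc(C(F)(F)F)cc1)c1nc(C(F)(F)F)c(C(=O)N/N=C/c2cc(C(F)(F)F)cc(C(F)(F)F)c2)s1` has not been measured. It differs from compound 2 in one place: 4-(trifluoromethyl)phenyl in place of 2-fluorophenyl on a carbonyl carbon. Among the measured compounds shown here, no pair of measured compounds shows this same exchange on its own, so its effect in this assay cannot be read from the data; compounds 1 and 3 carry other changes at the same time and do not isolate it.

The step from compound 2 to compound 4 is therefore expected to stay within the scatter, with no direction beyond it, as a 1.1-fold higher number from compound 2 to compound 4 (0.06 log units; within the scatter). Compound 4 is estimated at 7 ug/mL, within a range from 3 ug/mL to 16 ug/mL.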

Compound 4, half-maximal inhibitory concentration: 7.37 ug/mL
Beside the measured number, compound 4's estimate is 1.1-fold (0.02 log units) below it, within the range that was stated.
By their numbers in this assay, from the lowest: compounds 2, 4 and 1 (each within the scatter of the next); then compound 3.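

In this assay, among the compounds shown here, 4-(trifluoromethyl)phenyl in place of 2-fluorophenyl on a carbonyl carbon gives a 1.2-fold higher number from compound 2 to compound 4 (0.08 log units; within the scatter) and so provides the first reading of a change at this place alone. With the rest of compound 2 held fixed, the place accepts 10 heavy atoms instead of 7, and the fluorine count on the aromatic ring goes from 1 to 3, with no separation beyond the scatter. Nothing available accounts for this result.

Still open, going by these compounds, is whether this place stays as tolerant with a phenyl ring carrying a carboxylic acid or an amine, or with a non-aromatic group such as cyclohexyl. The compounds shown also leave open whether the same exchange reads alike when the other end of compound 2 differs, as it does in compound 1.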